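The compounds below may be only part of what the source reports. "The series", "measured", "known", "first", "only" and "open" are said of these compounds alone.

Measured so far in an ADME assay on Raji cells (Homo sapiens) for cytotoxicity, with a stated time of 72 h; a lower number here means that less compound is needed, a higher number that more compound is needed for the effect:
Compound 1, `Cc1cc(NC(=O)Nc2ccccc2F)c2ccccc2n1`, gives > 25000 nM, which is a limit of the assay.
Compound 2, `Cc1cc(NC(=O)Nc2ccc(F)cc2)c2ccccc2n1`, gives > 25000 nM, which is a limit of the assay.
Compound 3, `Cc1cc(NC(=O)Nc2ccccc2N)c2ccccc2n1`, gives > 25000 nM, which is a limit of the assay.

Compound 2 thus stands only at a limit on the numbers shown, as do the two other compounds, all three sitting at the limit of > 25000 nM in this assay, at which 3 of the 3 values shown sit. Compound 4, `Cc1cc(NC(=O)Nc2ccc(C(C)(C)C)cc2)c2ccccc2n1`, differs from compound 2 by tert-butyl in place of fluoro on an aromatic carbon. The steps measured around compound 2, a step that the two limits leave unreadable from compound 1 to compound 2 and a step that the two limits leave unreadable from compound 2 to compound 3, together with a step that the two limits leave unreadable from compound 1 to compound 3, cannot be read in size. Among the compounds with values here, no measured step therefore bears on the change to tert-butyl, and no step beyond the scatter is expected in this assay in either direction. Compound 4 is expected to give 30000 nM, with a range from 10000 nM to 100000 nM, which means an expected step that the limit leaves unreadable from compound 2 to compound 4.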

Compound 4, half-maximal effective concentration: > 25000 nM
Compound 4 was reported as a limit (the forecaster's own chance of this, stated with the estimate: 80%); the middle value does not contradict the limit.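

Compound 2 and compound 4 both stand at a limit, so the step between them cannot be read. The compounds shown leave open which change to the shared core, if any, would give a readable value in this assay: the limit of > 25000 nM in this assay, at which 4 of the 4 values shown sit.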